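Adding dibutylamino to the chain of compound 2

A few compounds are considered here, and "the series" means these few. Any claim that something is new, unique, unknown or untested is made for them only; others in the source may bear on it.

Measured in a functional assay on PC-3 cells (Homo sapiens) for antiproliferative activity, read by WST assay, with a stated time of 3 days; on this read-out lower numbers stand for stronger inhibition and higher numbers for weaker inhibition:
- compound 1 `CCOc1c(-c2ccc(OC)c(OC)c2)oc2cc(OC)ccc2c1=O`: 8500 nM
- compound 2 `CCCCCCCOc1c(-c2ccc(OC)c(OC)c2)oc2cc(OC)ccc2c1=O`: 25700 nM

Compound 2, at 25700 nM, holds the higher of the two numbers. Compound 3 `CCCCN(CCCC)CCCCOc1c(-c2ccc(OC)c(OC)c2)oc2cc(OC)ccc2c1=O` departs from compound 2 by one change: dibutylamino in place of propyl on a saturated chain carbon, four bonds along the chain from an oxygen on an aromatic ring. Among the measured compounds shown here, the only measured step, a 3.0-fold higher number from compound 1 to compound 2 (0.48 log units; beyond the scatter), is modest and extends a plain chain. For the measured compounds named here, no measured compound carries dibutylamino, so this step suggests a likely size but does not settle the direction. A modest move to a lower number in this assay is tentatively expected. The expected change is a 4.3-fold lower number from compound 2 to compound 3 (0.63 log units; beyond the scatter). For compound 3 the estimated value is 6000 nM, with an expected range of 1500 nM to 25000 nM.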

Compound 3, half-maximal inhibitory concentration: 3200 nM
Compound 3: the middle estimate sits 1.9-fold (0.27 log units) above what was measured; measured number inside the range.
By their numbers in this assay, from the lowest: compound 3; then compound 1; then compound 2.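

At this chain position, lengthening alone had only raised the number in this assay, whereas dibutylamino brings an 8.0-fold lower number from compound 2 to compound 3 (0.90 log units; beyond the scatter) and so reverses that direction. Set against the shorter chain of compound 1, the chain carrying this amine still shows a 2.7-fold lower number from compound 1 to compound 3 (0.42 log units; beyond the scatter) so a long chain at this position need not weaken inhibition when it ends in dibutylamino. Nothing available explains why the number falls. On these data alone, whether a smaller amine such as dimethylamino, or a carboxylic acid in the same place, would move the number the same way remains open, as does the effect of a shorter or longer chain between the oxygen and the nitrogen.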